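Bromo to methoxy on the sulfonamide aryl ring

A few compounds are considered here, and "the series" means these few. Any claim that something is new, unique, unknown or untested is made for them only; others in the source may bear on it.

Going by the values given here, compound 2 `O=C(c1ccc(OCCCN2CC[C@H](NS(=O)(=O)c3ccc(Br)cc3)C2)cc1)C1CC1` gives 290 nM in an assay on isolated protein for binding affinity to histamine H2 receptor (Homo sapiens) (on this read-out higher numbers stand for weaker inhibition and lower numbers for stronger inhibition), the lowest of the three numbers measured so far. Compound 1 `Cc1ccc(S(=O)(=O)N[C@H]2CCN(CCCOc3ccc(C(=O)C4CC4)cc3)C2)cc1` carries methyl where compound 2 carries bromo. In this assay compound 1 gives 380 nM. The step is a 1.3-fold lower number from compound 1 to compound 2 (0.12 log units; within the scatter). Among the compounds with values here, compound 3 `O=C(N[C@H]1CCN(CCCOc2ccc(C(=O)C3CC3)cc2)C1)c1csc(-c2cccnc2)n1`, in which the sulfonamide is replaced by an amide, gives 4000 nM in this assay, a clearly higher number than compound 2, with no single-point step defined between them.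

Compound 4 `COc1ccc(S(=O)(=O)N[C@H]2CCN(CCCOc3ccc(C(=O)C4CC4)cc3)C2)cc1` differs from compound 2 by methoxy in place of bromo on an aromatic carbon. Within the data shown here, the only measured step that bears on this change is the substituent exchange at the same aromatic carbon from compound 1 to compound 2, which stayed within the scatter. A similar outcome is expected for compound 4, with no step beyond the scatter in this assay; the estimated step is a 1.4-fold higher number from compound 2 to compound 4 (0.14 log units; within the scatter). Compound 4 is therefore expected to give about 400 nM in this assay, with a range from 150 nM to 1100 nM.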

Compound 4, inhibition constant: 1000 nM
The estimate for compound 4 lay 2.5-fold (0.40 log units) below the measured number, within the range that was stated.
By their numbers in this assay, from the lowest: compounds 2 and 1 (each within the scatter of the next); then compound 4; then compound 3.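

In this assay, the aromatic carbon para to a large group responds to its substituent: methoxy in place of bromo gives a 3.4-fold higher number from compound 2 to compound 4 (0.54 log units; beyond the scatter), and methoxy in place of methyl gives a 2.6-fold higher number from compound 1 to compound 4 (0.42 log units; beyond the scatter). Compound 1 and compound 2 alone showed no separation at this carbon, since methyl and bromo stayed within the scatter of each other; compound 4 now shows that this tolerance does not extend to every group, as both steps lie beyond the scatter while remaining modest in size. Nothing available explains why methoxy separates from methyl and bromo.

Going by these compounds, how trifluoromethyl or hydroxy at the same carbon would compare with bromo and methoxy remains open. Also open, on these data alone, is whether ethoxy would move the number further from compound 2 than methoxy does.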